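The compounds below may be only part of what the source reports. "The series", "measured", "known", "first", "only" and "open" are said of these compounds alone.

Measured in an assay on HEK293 cells for binding affinity to prostaglandin E2 receptor EP4 subtype (Rattus norvegicus); on this read-out higher numbers stand for weaker inhibition and lower numbers for stronger inhibition:
compound 1 `O=C(O)c1ccc(CCCN2C(=O)CC[C@@H]2CCC(O)Cc2ccccc2)s1` gives 21 nM
compound 2 `O=C(O)c1ccc(CCCN2C(=O)CC[C@@H]2CCC(O)Cc2ccc3ccccc3c2)s1` gives 65 nM
compound 3 `O=C(O)c1ccc(CCCN2C(=O)CCC2CCC(O)Cc2ccc(F)cc2)cc1` gives 2770 nM

Compound 3 stands highest of the three numbers in this assay. The nearest value is that of compound 2 at 65 nM; compound 1, at 21 nM, lies furthest away. Both gaps lie beyond the scatter. Within the data shown here, compound 3 also differs from compounds 1 and 2 in its core, so no single step links it to either.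

Compound 4 `O=C(O)c1ccc(CCCN2C(=O)CCC2CCC(O)Cc2cccc(Cl)c2)cc1` is not yet measured. The change from compound 3 is 3-chlorophenyl in place of 4-fluorophenyl on a saturated chain carbon, two bonds along the chain from an oxygen on a saturated carbon. Among the measured compounds shown here, the only measured step at the same place is a 3.1-fold higher number from compound 1 to compound 2 (0.49 log units; beyond the scatter), a change of the aryl group on a different core and of a different kind, so it bears on compound 4 only loosely. It shows that swapping the aryl group at this position moved this assay by a modest amount; an exchange of one halogenated phenyl for another is a smaller change than phenyl to naphthalen-2-yl. A step within the scatter, or at most modest in either direction, is expected. The estimate for compound 4 in this assay is 2500 nM, with a range from 900 nM to 7000 nM, corresponding to an expected step of a 1.1-fold lower number from compound 3 to compound 4 (0.04 log units; within the scatter).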

Compound 4, half-maximal inhibitory concentration: 42 nM
Compound 4: the middle estimate sits 60-fold (1.77 log units) above what was measured; the measured number lies below the stated range.
By their numbers in this assay, from the lowest: compounds 1, 4 and 2 (each within the scatter of the next, the first and the last beyond it); then compound 3.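

In this assay, among these compounds, the aryl group on a saturated chain carbon, two bonds along the chain from an oxygen on a saturated carbon, proves a far more sensitive point than the one earlier step suggested: the change from 4-fluorophenyl to 3-chlorophenyl gives a 66-fold lower number from compound 3 to compound 4 (1.82 log units; beyond the scatter), whereas the larger-looking swap of phenyl for naphthalen-2-yl on the core of compound 1 gave a 3.1-fold higher number from compound 1 to compound 2 (0.49 log units; beyond the scatter). The high number of compound 3 is therefore not set by its core alone, since compound 4 shares that core and gives 42 nM. No supporting data on the origin of this step are available here.

The change alters both the halogen and where it sits, so the compounds shown cannot assign the step to either; 4-chlorophenyl or 3-fluorophenyl on the core of compound 3 would separate the two. Also open is whether 3-chlorophenyl would have any comparable effect on the core of compound 1, where the only aryl groups shown are phenyl and naphthalen-2-yl.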